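A few compounds are considered here, and "the series" means these few. Any claim that something is new, unique, unknown or untested is made for them only; others in the source may bear on it.

Measured compounds and their numbers in a functional assay on HeLa cells (Homo sapiens) for antiproliferative activity, with a stated time of 24 h; on this read-out higher numbers stand for weaker inhibition and lower numbers for stronger inhibition:
- compound 1 `NC(=O)c1c(NC(=O)c2ccccc2Cl)sc2c1CCN(C(=S)Nc1cccc3ccccc13)C2`, 30800 nM
- compound 2 `NC(=O)c1c(NC(=O)c2ccccc2Cl)sc2c1CCN(C(=S)Nc1ccccc1Br)C2`, 24600 nM
- compound 3 `NC(=O)c1c(NC(=O)c2ccccc2Cl)sc2c1CCN(C(=S)Nc1ccccc1I)C2`, 29000 nM

All three share one core and differ only in the aryl group on the thiourea nitrogen. Compound 3 holds the second highest number of the three; its nearest neighbour is compound 1, with a 1.1-fold lower number from compound 1 to compound 3 (0.03 log units; within the scatter), and its furthest is compound 2, with a 1.2-fold higher number from compound 2 to compound 3 (0.07 log units; within the scatter). Both gaps sit inside the scatter, so the three compounds cannot be ordered against each other on these numbers.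

Compound 4 `COc1ccc(NC(=S)N2CCc3c(sc(NC(=O)c4ccccc4Cl)c3C(N)=O)C2)cc1` is the next member. Relative to compound 3 the change is 4-methoxyphenyl in place of 2-iodophenyl on an amide-type nitrogen. For the measured compounds named here, no measured step involves a methoxy group, so the bearing of earlier steps is indirect: the exchanges of aryl groups on the same nitrogen, a 1.3-fold lower number from compound 1 to compound 2 (0.10 log units; within the scatter) and a 1.1-fold lower number from compound 1 to compound 3 (0.03 log units; within the scatter), and the halogen swap a 1.2-fold higher number from compound 2 to compound 3 (0.07 log units; within the scatter), all left this assay flat. On that basis a further aryl exchange at the same place is expected to move this assay by no more than the scatter, with no direction preferred; the expected step is a 1.0-fold lower number from compound 3 to compound 4 (0.02 log units; within the scatter).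

Compound 4 is therefore estimated at 28000 nM in this assay, within a range from 11000 nM to 70000 nM.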

Compound 4, half-maximal inhibitory concentration: 36400 nM
Beside the measured number, compound 4's estimate is 1.3-fold (0.11 log units) below it; low and high end bracket the measured number.
By their numbers in this assay, from the lowest: compounds 2, 3, 1 and 4 (each within the scatter of the next).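

In this assay, 4-methoxyphenyl on the amide-type nitrogen gives a 1.3-fold higher number from compound 3 to compound 4 (0.10 log units; within the scatter), a 1.5-fold higher number from compound 2 to compound 4 (0.17 log units; within the scatter) and a 1.2-fold higher number from compound 1 to compound 4 (0.07 log units; within the scatter), all within the scatter, even though this group counts one hydrogen-bond acceptor where 2-iodophenyl counts none. For the compounds shown here, the flat picture at this position therefore now covers naphthalen-1-yl, 2-bromophenyl, 2-iodophenyl and 4-methoxyphenyl, with no compound among the four going against it, and it extends to an aryl group that carries oxygen and no halogen. No supporting data bear on why this assay stays flat across these exchanges.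

From the compounds shown here alone, the change from 2-iodophenyl to 4-methoxyphenyl alters both the substituent and its numbered place on the ring, so the effect of each alone stays open, and 2-methoxyphenyl or 4-iodophenyl would separate the two. Also open, going by these compounds, is whether the flat picture survives a larger departure at this nitrogen, such as a phenyl ring bearing a carboxylic acid or an aminoethyl chain, or a simple alkyl chain in place of the aryl ring, and whether any change to the shared core moves this assay beyond the scatter.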